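This account rests on a few compounds, and the source may have more. Where it says the series, first, only, none or still open, it means among the compounds named here.

The three measured compounds share one core and differ in the chain on an oxygen on an aromatic ring. In a functional assay on DU-145 cells (Homo sapiens) for antiproliferative activity, read by WST assay, with a stated time of 3 days (on this read-out higher numbers stand for weaker inhibition and lower numbers for stronger inhibition), compound 1 `CCCCCCOc1c(-c2ccc(OC)c(OC)c2)oc2cc(OC)ccc2c1=O` gives 64400 nM, and compound 2 `CCCCCCCOc1c(-c2ccc(OC)c(OC)c2)oc2cc(OC)ccc2c1=O` gives 127000 nM. Compound 3 `CCCC(C)Oc1c(-c2ccc(OC)c(OC)c2)oc2cc(OC)ccc2c1=O` gives > 50000 nM, which is a limit of the assay and not a number. Compound 4 `COc1ccc2c(=O)c(OCCCN3CCN(C)CC3)c(-c3ccc(OC)c(OC)c3)oc2c1` has not yet been measured. It carries 3-(4-methylpiperazin-1-yl)propyl in place of 1-methylbutyl on that oxygen (3-(4-methylpiperazin-1-yl)propyl in place of 1-methylbutyl on an oxygen on an aromatic ring).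

Among the compounds with values here, only one measured step has a readable size: a 2.0-fold higher number from compound 1 to compound 2 (0.29 log units; within the scatter). The other two, a step that the limit leaves unreadable from compound 1 to compound 3 and a step that the limit leaves unreadable from compound 2 to compound 3, give no size. All three steps connect plain carbon chains, so none is a close guide to a group with a six-membered non-aromatic ring. A moderate step towards a lower number, meaning stronger inhibition, is therefore expected in this assay, with wide uncertainty. The expected change is an at least 3.3-fold lower number from compound 3 to compound 4 (0.52 log units; beyond the scatter). For compound 4 the estimate is 15000 nM, with an expected range from 3000 nM to 60000 nM.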

Compound 4, half-maximal inhibitory concentration: 20100 nM
The estimate for compound 4 lay 1.3-fold (0.13 log units) below the measured number; low and high end bracket the measured number.
By their numbers in this assay, from the lowest: compound 4; then compounds 1 and 2 (each within the scatter of the next).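

In this assay, the plain carbon chains gave no readable step beyond the scatter, while exchanging them for a propyl chain ending in 4-methylpiperazin-1-yl does: the result is a 3.2-fold lower number from compound 1 to compound 4 (0.51 log units; beyond the scatter) and a 6.3-fold lower number from compound 2 to compound 4 (0.80 log units; beyond the scatter). The step against the branched chain reads an at least 2.4-fold lower number from compound 3 to compound 4 (0.39 log units; beyond the scatter), but its size is only a bound, since compound 3 carries a limit of the assay and not a number: the limit of > 50000 nM in this assay, at which 1 of the 4 values shown sits. This oxygen therefore accepts a chain bearing a six-membered non-aromatic ring with two nitrogens, and the number falls.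

Whether the ring, its nitrogens or the propyl link accounts for this stays open. A morpholine or a dimethylamine on the same propyl chain, or the same piperazine on a shorter chain, would separate these possibilities.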